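The compounds below may be only part of what the source reports. "The series", "measured", "known", "first", "only" and "open" are said of these compounds alone.

Measured in an ADME assay on Vero cells (Chlorocebus sabaeus) for cytotoxicity; a higher number here means that more compound is tolerated, a lower number that less compound is tolerated:
- compound 1 `CC(=O)Nc1ccc(-c2nc3cc(C(F)(F)F)ccc3n2C2CCCCC2)cc1` — 30000 nM
- compound 2 `CN1CCN(CC(=O)Nc2ccc(-c3nc4cc(C(F)(F)F)ccc4n3C)cc2)CC1` — only the limit > 100000 nM
- compound 3 `CC(=O)Nc1ccc(-c2nc3cc(C(F)(F)F)ccc3[nH]2)cc1` — 50000 nM

Compound 3 holds the highest of the two numbers in this assay; the nearest is compound 1, a step of a 1.7-fold higher number from compound 1 to compound 3 (0.22 log units; within the scatter), so the two sit within the scatter. Compound 2 gives no number, as the limit of > 100000 nM in this assay, at which 1 of the 3 values shown sits.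

Compound 4 `CC(=O)Nc1ccc(-c2nc3cc(C(F)(F)F)ccc3n2C)cc1` is made from compound 3 by methyl in place of hydrogen on an aromatic nitrogen. Going by the values given here, the only measured step at this aromatic nitrogen, hydrogen in place of cyclohexyl, was a 1.7-fold higher number from compound 1 to compound 3 (0.22 log units; within the scatter), within the scatter, and a much smaller group now enters the same place. No step beyond the scatter is therefore expected in this assay.

Compound 4 is estimated at 50000 nM, range 25000 nM to 100000 nM, an expected step of no change at the digits printed from compound 3 to compound 4 (within the scatter).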

Compound 4, half-maximal cytotoxic concentration: > 100000 nM
Compound 4: only a limit was reported; the forecaster's own chance of this, stated with the estimate: 20%; middle value at least 2.0-fold (0.30 log units) from the limit.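

In this assay, going by these compounds alone, methyl in place of cyclohexyl gives the only step at this aromatic nitrogen that lies beyond the scatter: an at least 3.3-fold higher number from compound 1 to compound 4 (0.52 log units; beyond the scatter). Methyl in place of hydrogen gives a step whose floor still lies within the scatter: an at least 2.0-fold higher number from compound 3 to compound 4 (0.30 log units; that floor lies within the scatter). The step between compound 2 and compound 4 cannot be read, and the series now meets the same limit twice: the limit of > 100000 nM in this assay, at which 2 of the 4 values shown sit.

Open, as far as these compounds go, is how an ethyl group, an isopropyl group or a longer chain on this nitrogen would read in this assay. Also open, from the compounds shown here alone, is whether an amine or a carboxylic acid on such a chain would keep compounds at the limit.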